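A few compounds are considered here, and "the series" means these few. Any claim that something is new, unique, unknown or untested is made for them only; others in the source may bear on it.

Working notes on a small series sharing one core, all tested in a functional assay on MDA-MB-231 cells (Homo sapiens) for cytotoxicity, read by MTT assay, with a stated time of 72 h; a lower number here means a stronger inhibitor, a higher number a weaker inhibitor.

Compound 2 `Cc1ccccc1NC(=O)CN1CCN(c2nnc(Cc3ccccc3)c3ccccc23)CC1` serves as the reference point; in this assay compound 2 gives 17300 nM. Compound 1 `O=C(CN1CCN(c2nnc(Cc3ccccc3)c3ccccc23)CC1)Nc1ccc(F)c(F)c1` differs from compound 2 by 3,4-difluorophenyl in place of 2-methylphenyl on an amide-type nitrogen; in this assay compound 1 gives 2750 nM, a step of a 6.3-fold lower number from compound 2 to compound 1 (0.80 log units; beyond the scatter). Compound 3 `Cc1ccccc1NC(=O)CN1CCN(c2nnc(Cc3ccncc3)c3ccccc23)CC1` differs from compound 2 at the other end of the molecule, by pyridin-4-yl in place of phenyl on a saturated chain carbon bound to an aromatic carbon; in this assay compound 3 gives 200 nM, a step of an 87-fold lower number from compound 2 to compound 3 (1.94 log units; beyond the scatter). Compound 3 stands lowest of the three measured compounds, its steps to both others beyond the usual scatter.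

Compound 4 `O=C(CN1CCN(c2nnc(Cc3ccncc3)c3ccccc23)CC1)Nc1ccc(F)c(F)c1` is not yet measured. Relative to compound 3 it carries 3,4-difluorophenyl in place of 2-methylphenyl on an amide-type nitrogen. This is the same change as the one from compound 2 to compound 1, made at the same place with the same neighbour, and it occurs twice among the compounds shown. Going by the values given here, the one measured instance of it gave a 6.3-fold lower number from compound 2 to compound 1 (0.80 log units; beyond the scatter).

Among the compounds with values here, for compound 4 in this assay the expected step is about a 4.0-fold lower number from compound 3 to compound 4 (0.60 log units; beyond the scatter), resting on the single precedent a 6.3-fold lower number from compound 2 to compound 1 (0.80 log units; beyond the scatter). Within the data shown here, the uncertainty is wider than that precedent alone suggests: only one pair carries this change, and compound 3 already sits far below compound 2. Compound 4 is estimated at 50 nM in this assay, with a likely range from 15 nM to 200 nM.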

Compound 4, half-maximal inhibitory concentration: 0.84 nM
The estimate for compound 4 lay 60-fold (1.77 log units) above the measured number; the whole stated range lies above it.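

In this assay, 3,4-difluorophenyl in place of 2-methylphenyl on the amide-type nitrogen gives a 240-fold lower number from compound 3 to compound 4 (2.38 log units; beyond the scatter), so the direction of the earlier step carries over to the core bearing pyridin-4-yl but its size does not: the same change on two cores in this assay, a 6.3-fold lower number (0.80 log units; beyond the scatter) from compound 2 to compound 1 and a 240-fold lower number (2.38 log units; beyond the scatter) from compound 3 to compound 4, 38-fold (1.58 log units) apart, beyond the scatter of two such steps

Read the other way round, pyridin-4-yl in place of phenyl gives a 3300-fold lower number from compound 1 to compound 4 (3.52 log units; beyond the scatter), and this step also keeps its direction while changing in size with the group on the amide-type nitrogen: the same change on two cores in this assay, an 87-fold lower number (1.94 log units; beyond the scatter) from compound 2 to compound 3 and a 3300-fold lower number (3.52 log units; beyond the scatter) from compound 1 to compound 4, 38-fold (1.58 log units) apart, beyond the scatter of two such steps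

These two comparisons rest on the same four compounds, so they show one instance of two changes that are not independent, with compound 4 lower than a simple sum of the separate steps would give; they do not show why, nor that the same holds for any other pair of groups in this series.

The compounds shown leave open whether both fluorines are needed, since neither an unsubstituted phenyl nor a phenyl carrying a single fluorine appears on the amide-type nitrogen of either core. They also leave open whether the large step on the pyridin-4-yl core extends to other groups there, such as a chlorophenyl or a methoxyphenyl, or to a longer chain in place of the saturated chain carbon.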